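Trifluoromethylphenyl position on the shared core

The compounds below may be only part of what the source reports. "The series", "measured", "known", "first", "only" and "open" are said of these compounds alone.

Measured so far:
- compound 1 `Oc1ccc(-c2cc(-c3cccc(F)c3)cc(-c3ccc(O)cc3)n2)cc1`: > 50000 nM
- compound 2 `Oc1ccc(-c2cc(-c3cccc(C(F)(F)F)c3)cc(-c3cccc(O)c3)n2)cc1`: 2630 nM
- compound 3 `Oc1ccc(-c2cc(-c3ccccc3C(F)(F)F)cc(-c3ccc(O)cc3)n2)cc1`: > 50000 nM

In a functional assay on T47D cells (Homo sapiens) for inhibition (a higher number here means a weaker inhibitor, a lower number a stronger inhibitor), compound 1 sits at a limit, > 50000 nM. Compound 3 likewise sits at the limit, > 50000 nM; (the limit of > 50000 nM in this assay, at which 2 of the 3 values shown sit). Compound 2, carrying a 3-hydroxyphenyl in place of one 4-hydroxyphenyl, gives a number, 2630 nM. The step from compound 1 to compound 3 is a step that the two limits leave unreadable from compound 1 to compound 3.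

As far as these compounds go, compound 4 `Oc1ccc(-c2cc(-c3cccc(C(F)(F)F)c3)cc(-c3ccc(O)cc3)n2)cc1` is untested. It differs from compound 3 by 3-(trifluoromethyl)phenyl in place of 2-(trifluoromethyl)phenyl on an aromatic carbon. Among the measured compounds shown here, no measured step reports this change directly. For the measured compounds named here, the only measured compound with a 3-(trifluoromethyl)phenyl is compound 2 at 2630 nM. Compound 3 itself sits at a limit. A step between these two compounds cannot be read. Compound 4 is expected to fall near 8000 nM (range 1500 nM to 50000 nM), an estimated step of an at least 6.2-fold lower number from compound 3 to compound 4 (0.79 log units; beyond the scatter).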

Compound 4, half-maximal inhibitory concentration: > 50000 nM
Compound 4 ended at the assay's limit; the forecaster's own chance of this, stated with the estimate: 35%; at least 6.2-fold (0.79 log units) between middle value and limit.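

In this assay, 3-(trifluoromethyl)phenyl in place of 2-(trifluoromethyl)phenyl yields no readable number, and compound 4 stays at a limit, > 50000 nM. With 3-(trifluoromethyl)phenyl held fixed, 4-hydroxyphenyl in place of 3-hydroxyphenyl gives an at least 19-fold higher number from compound 2 to compound 4 (1.27 log units; beyond the scatter), so the number of compound 2 goes with its 3-hydroxyphenyl, not with the 3-(trifluoromethyl)phenyl alone. The steps from compound 1 and from compound 3 to compound 4 cannot be read: the limit of > 50000 nM in this assay, at which 3 of the 4 values shown sit.

Open, as far as these compounds go, is whether 3-hydroxyphenyl also gives a number alongside 3-fluorophenyl or 2-(trifluoromethyl)phenyl. Also open, from the compounds shown here alone, is whether an amine or a methoxy in place of that hydroxyl keeps a measurable value.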